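Cytotoxicity notes on the nitrobenzyl analogue of compound 2

This account rests on a few compounds, and the source may have more. Where it says the series, first, only, none or still open, it means among the compounds named here.

Compound 2 `COC(=O)C[C@H](NC(=O)OC(C)(C)C)C(=O)N(Cc1ccc(C(F)(F)F)cc1)C1(C(=O)NCc2ccccc2)CCN(Cc2ccccc2)CC1` stands in an ADME assay on MDCK cells (Canis lupus familiaris) for cytotoxicity, read by microscopy, with a stated time of 72 h (on this read-out lower numbers stand for higher toxicity in this test and higher numbers for lower toxicity in this test), at 84000 nM. Compound 1 `COC(=O)C[C@H](NC(=O)OC(C)(C)C)C(=O)N(C1CC1)C1(C(=O)NCc2ccccc2)CCN(Cc2ccccc2)CC1` gives 84000 nM in this assay, and no change at the digits printed from compound 1 to compound 2 (within the scatter). Compound 3 `COC(=O)C[C@H](NC(=O)OC(C)(C)C)C(=O)N(Cc1ccc([N+](=O)[O-])cc1)C1(C(=O)NCc2ccccc2)CCN(Cc2ccccc2)CC1` differs from compound 2 by nitro in place of trifluoromethyl on an aromatic carbon, on an aromatic carbon of a six-membered aromatic ring of carbon only. For the measured compounds named here, only the step from compound 1 to compound 2 bears on this change, and it showed no movement beyond the scatter even for a much larger swap of the whole group on the amide-type nitrogen. The step from compound 2 to compound 3 is therefore expected to be no change at the digits printed from compound 2 to compound 3 (within the scatter), no change beyond the scatter. Compound 3 is estimated at 84000 nM, with a range from 42000 nM to 168000 nM.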

Compound 3, minimum cytotoxic concentration: 20000 nM
Estimate against measurement, compound 3: 4.2-fold (0.62 log units) above; the measured number lies below the stated range.
By their numbers in this assay, from the lowest: compound 3; then compounds 1 and 2 (each within the scatter of the next).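

In this assay nitro in place of trifluoromethyl on the aromatic carbon gives a 4.2-fold lower number from compound 2 to compound 3 (0.62 log units; beyond the scatter) and so registers at this place, a change the earlier pair could not show. Measured from the cyclopropyl compound, 4-nitrobenzyl gives a 4.2-fold lower number from compound 1 to compound 3 (0.62 log units; beyond the scatter) while 4-(trifluoromethyl)benzyl gives no change at the digits printed from compound 1 to compound 2 (within the scatter) on the same amide-type nitrogen, so the outcome there turns on the group carried by the benzyl ring. No evidence given here accounts for the lower number with nitro. Going by these compounds, whether an amine, a nitrile or a carboxylic acid at this place would track nitro or trifluoromethyl remains open.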